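Swapping Fluoro for Hydroxy on the Benzamide Ring

This account rests on a few compounds, and the source may have more. Where it says the series, first, only, none or still open, it means among the compounds named here.

Measured in a functional assay on MCF7 cells (Homo sapiens) for antiproliferative activity, read by MTT assay, with a stated time of 48 h; a higher number here means a weaker inhibitor, a lower number a stronger inhibitor:
- compound 1 `COc1cccc(C(=O)Nc2nnc(/C=C/c3cc(OC)c(OC)c(OC)c3Br)s2)c1`: 170 nM
- compound 2 `COc1cc(/C=C/c2nnc(NC(=O)c3cccc(F)c3)s2)c(Br)c(OC)c1OC`: 340 nM

Going by the values given here, with only two numbers so far, compound 2 at 340 nM cannot be told apart from compound 1 at 170 nM, since the two lie within the scatter of each other. The next candidate is compound 3 `COc1cc(/C=C/c2nnc(NC(=O)c3cccc(O)c3)s2)c(Br)c(OC)c1OC`, which carries hydroxy in place of fluoro on an aromatic carbon, turning 3-fluorophenyl into 3-hydroxyphenyl (hydroxy in place of fluoro on an aromatic carbon). Among the compounds with values here, one measured step bears on this spot: fluoro in place of methoxy gave a 2.0-fold higher number from compound 1 to compound 2 (0.30 log units; within the scatter). Within the data shown here, no hydroxy compound has been measured yet, so this is thin evidence. Even so, the only change seen at this spot stayed within the scatter, so no clear shift in either direction is expected in this assay. The expected size is a 1.3-fold lower number from compound 2 to compound 3 (0.12 log units; within the scatter). For compound 3 the estimated value is 260 nM, with an expected range of 90 nM to 750 nM.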

Compound 3, half-maximal inhibitory concentration: 360 nM
Beside the measured number, compound 3's estimate is 1.4-fold (0.14 log units) below it, and the stated range covers the measured number.
By their numbers in this assay, from the lowest: compounds 1, 2 and 3 (each within the scatter of the next, the first and the last beyond it).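

In this assay, hydroxy in place of fluoro gives a 1.1-fold higher number from compound 2 to compound 3 (0.02 log units; within the scatter) and so leaves the two groups indistinguishable here, even though hydroxy counts as a hydrogen-bond donor and acceptor and fluoro as neither. Taking the methyl off the oxygen of the methoxy group gives a 2.1-fold higher number from compound 1 to compound 3 (0.33 log units; beyond the scatter) as the first step at this position to lie beyond the scatter, though it is only a modest one. No measurement at hand offers an explanation for either step.

The compounds shown leave open whether an amine or a carboxylic acid on this aromatic carbon would fall in the same range. They also leave open whether a longer chain on the oxygen, such as ethoxy, would give a value different from those of the methoxy and hydroxy compounds.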